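A few compounds are considered here, and "the series" means these few. Any claim that something is new, unique, unknown or untested is made for them only; others in the source may bear on it.

Compound 1 `N#Cc1ccc(NC(=O)c2ccc(-c3cccnc3)cc2O)cc1`: 7940 nM
Compound 2 `Cc1cccc(O)c1C(=O)Nc1ccc(C#N)cc1`: 7940 nM

In a functional assay on KG-1 cells (Homo sapiens) for cytotoxicity, read by luminescence and CellTiter-Glo, with a stated time of 3 days (a higher number here means a weaker inhibitor, a lower number a stronger inhibitor), compound 1 stands level with compound 2, within the usual scatter of repeated measurements. Compound 3 `N#Cc1ccc(NC(=O)c2ccc(Br)cc2O)cc1` changes compound 1 in one place: bromo replaces pyridin-3-yl on an aromatic carbon, (bromo in place of pyridin-3-yl on an aromatic carbon). Going by the values given here, no measured pair shows what this swap does, so the only guide is the level pair, compound 1 at 7940 nM and compound 2 at 7940 nM. The expected change is a 1.1-fold lower number from compound 1 to compound 3 (0.05 log units; within the scatter), which is not expected to exceed the scatter or to have a clear direction. Compound 3 is estimated at 7000 nM, with an expected range from 2500 nM to 20000 nM.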

Compound 3, half-maximal inhibitory concentration: 1450 nM
For compound 3 the middle estimate is 4.8-fold (0.68 log units) above the measured one, and the stated range ends above it.
By their numbers in this assay, from the lowest: compound 3; then compounds 1 and 2 (each within the scatter of the next).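

Putting bromo in place of pyridin-3-yl on this aromatic carbon gives a 5.5-fold lower number from compound 1 to compound 3 (0.74 log units; beyond the scatter) in this assay. The pyridin-3-yl ring is therefore not needed for cytotoxic activity here, and a single bromine atom at this position does better in these cells. Nothing available explains why this swap lowers the number.

From the compounds shown here alone, how a methoxy group, chloro or an amine on this same carbon would compare remains open. It is also unclear whether bromo itself matters or whether simply removing the ring accounts for the step.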